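Series notes: ester variation and buffer stability

The source may hold more compounds than are shown below. What is called first, only, known or untested is meant among the compounds shown, and "the series" means these compounds.

Compound 3 `CCOC(=O)OCOC(=O)C1=C(S[C@@H]2CN[C@H](C(=O)Nc3cccc(C(=O)O)c3)C2)[C@H](C)[C@@H]2[C@@H]([C@@H](C)O)C(=O)N12` stands at a limit in a physicochemical assay for metabolic stability, read by LC-MS, in phosphate buffer, with a stated time of 3 h, at pH 7.4, tested at 50 uM; a higher number here means that more of the compound is left, a lower number that less of the compound is left: compound 3 gives > 95%, which is a limit of the assay and not a number. Compound 1 `C[C@@H](O)[C@H]1C(=O)N2C(C(=O)OCOC(=O)C3CCCCC3)=C(S[C@@H]3CN[C@H](C(=O)Nc4cccc(C(=O)O)c4)C3)[C@H](C)[C@H]12` likewise gives a limit, > 95%. Compound 2 `CC(C)OC(=O)C1=C(S[C@@H]2CN[C@H](C(=O)Nc3cccc(C(=O)O)c3)C2)[C@H](C)[C@@H]2[C@@H]([C@@H](C)O)C(=O)N12` also gives a limit, > 95%. All three sit at the limit of > 95% in this assay, at which 3 of the 3 values shown sit, so the steps a step that the two limits leave unreadable from compound 1 to compound 2, a step that the two limits leave unreadable from compound 1 to compound 3 and a step that the two limits leave unreadable from compound 2 to compound 3 cannot be read in size. Compound 4 `CCOC(=O)C1=C(S[C@@H]2CN[C@H](C(=O)Nc3cccc(C(=O)O)c3)C2)[C@H](C)[C@@H]2[C@@H]([C@@H](C)O)C(=O)N12` differs from compound 3 by methyl in place of (ethoxycarbonyl)oxy on a saturated chain carbon bound to an oxygen next to a carbonyl group. For the measured compounds named here, no measured step bears readably on this change, so no step beyond the scatter is expected in this assay. The step that the limit leaves unreadable from compound 3 to compound 4 is estimated accordingly. Compound 4 is expected to give 96% in this assay, within 88% to 100%.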

Compound 4, percent of the compound remaining: > 95%
Compound 4: only a limit was reported; the forecaster's own chance of this, stated with the estimate: 80%; the middle value does not contradict the limit.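

Compound 4 gives > 95%, a limit and not a number, so its steps from compound 1, compound 2 and compound 3 cannot be read in this assay; all values sit at one limit: the limit of > 95% in this assay, at which 4 of the 4 values shown sit.

The compounds shown leave open whether these esters differ at all in this assay.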